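One More Methoxy Group and an Expected Flat Response

The source may report more compounds than this note shows. Statements on the series, on what has been measured and on what is new or still open speak of the compounds shown alone.

Three measured compounds share one core and differ only in the aryl group on the carbonyl carbon. In a functional assay on SK-OV-3 cells (Homo sapiens) for cytotoxicity, read by sulforhodamine B assay, with a stated time of 48 h, tested at 1 uM (a lower number here means a stronger effect, a higher number a weaker effect of the compound at the concentration tested), compound 1 `COc1cc(-c2cc(/C=C/C(=O)c3ccc(N)cc3)[nH]n2)cc(OC)c1OC` gives 104%. Compound 2 `COc1cc(-c2cc(/C=C/C(=O)c3ccc(Cl)c(Cl)c3)[nH]n2)cc(OC)c1OC` gives 89%. Compound 3 `COc1ccc(C(=O)/C=C/c2cc(-c3cc(OC)c(OC)c(OC)c3)n[nH]2)cc1OC` gives 100%. Compound 3 thus stands second highest of the three, close to compound 1 and further from compound 2, as the steps of a number 4 percentage points lower from compound 1 to compound 3 (within the scatter) and a number 11 percentage points higher from compound 2 to compound 3 (beyond the scatter) show; the largest step seen is a number 15 percentage points lower from compound 1 to compound 2 (beyond the scatter). Compound 4 `COc1cc(C(=O)/C=C/c2cc(-c3cc(OC)c(OC)c(OC)c3)n[nH]2)cc(OC)c1OC` differs from compound 3 by methoxy in place of hydrogen on an aromatic carbon. Among the compounds with values here, no measured step swaps hydrogen for methoxy, and the whole set moves only modestly, so compound 4 is expected to show no change beyond the scatter, an estimated no change at the digits printed from compound 3 to compound 4 (within the scatter). Compound 4 is therefore estimated at 100%, within a range from 88% to 110%.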

Compound 4, a percentage reported as activity, at one concentration (the size of the read-out at that concentration, not a potency): 96%
Compound 4: middle estimate off by 4 percentage points, on the high side; the range from low to high includes it.
By their numbers in this assay, from the lowest: compounds 2, 4, 3 and 1 (each within the scatter of the next, the first and the last beyond it).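

Putting methoxy in place of hydrogen on this aromatic carbon, ortho to a methoxy group, gives a number 4 percentage points lower from compound 3 to compound 4 (within the scatter) in this assay. Within the data shown here, this is the first direct reading of this change, and it shows that a further methoxy on the aryl group at the carbonyl carbon leaves the read-out indistinguishable from that of compound 3. No measurement at hand offers an explanation for this result. From the compounds shown here alone, whether a hydroxyl group or a carboxylic acid on this same carbon would shift the read-out remains open. So does how these compounds behave at other concentrations.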